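Compound 4 and a Stereocentre Drawn Without Configuration

This account rests on a few compounds, and the source may have more. Where it says the series, first, only, none or still open, it means among the compounds named here.

In a functional assay on cells (Macrophage, Mus musculus) for activation (on this read-out higher numbers stand for an effect only at larger amounts of compound and lower numbers for an effect already at smaller amounts), compound 3 (`CCCCCCCCCCCC(=O)O[C@H](CCCCCCCCCCC)CC(=O)N[C@H](CCOP(=O)(O)O)C(=O)NCCC[C@H](COP(=O)(O)O)NC(=O)C[C@H](O)CCCCCCCCCCC`) gives 0.55 ug/mL, which places it between compound 1 (`CCCCCCCCCCCC(=O)O[C@H](CCCCCCCCCCC)CC(=O)N[C@@H](CCOP(=O)(O)O)C(=O)NCCC[C@H](COP(=O)(O)O)NC(=O)C[C@H](O)CCCCCCCCCCC`) at 0.15 ug/mL and compound 2 (`CCCCCCCCCCCC(=O)O[C@H](CCCCCCCCCCC)CC(=O)NC(CCOP(=O)(O)O)C(=O)NCCC[C@H](CO)NC(=O)C[C@H](O)CCCCCCCCCCC`) at 3.53 ug/mL. Compound 4 (`CCCCCCCCCCCC(=O)O[C@H](CCCCCCCCCCC)CC(=O)NC(CCOP(=O)(O)O)C(=O)NCCC[C@H](COP(=O)(O)O)NC(=O)C[C@H](O)CCCCCCCCCCC`) departs from compound 3 in one place: the two compounds have the same atoms and bonds; at least one stereo element is drawn with a configuration in one of them and without one in the other: 1 of 4 stereo elements differ; a stereocentre at a saturated chain carbon is drawn R in compound 3 and without a configuration in compound 4. The measured step that bears on this centre is a 3.7-fold higher number from compound 1 to compound 3 (0.56 log units; beyond the scatter), a modest change seen with the fact that compounds 1 and 3 differ only in the configuration as drawn. With that centre left open, the number for compound 4 is expected to fall inside the span of that step. The expected change is a 1.8-fold lower number from compound 3 to compound 4 (0.26 log units; within the scatter), toward a lower number and not beyond the scatter. For compound 4 the estimate is 0.3 ug/mL, with an expected range of 0.14 ug/mL to 0.65 ug/mL.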

Compound 4, half-maximal effective concentration: 0.083 ug/mL
Beside the measured number, compound 4's estimate is 3.6-fold (0.56 log units) above it; the whole stated range lies above it.
By their numbers in this assay, from the lowest: compounds 4 and 1 (each within the scatter of the next); then compound 3; then compound 2.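

In this assay, the centre left open does not put compound 4 inside the span of the two defined forms, as there is a 6.6-fold lower number from compound 3 to compound 4 (0.82 log units; beyond the scatter) with atoms and bonds unchanged: the fact that one of compounds 3 and 4 is drawn with a defined configuration and the other without, at the place where they differ Against the S form there is only a 1.8-fold lower number from compound 1 to compound 4 (0.26 log units; within the scatter): the fact that one of compounds 1 and 4 is drawn with a defined configuration and the other without, at the place where they differ With this centre undrawn in both, the larger effect is a 43-fold lower number from compound 2 to compound 4 (1.63 log units; beyond the scatter), which goes with a group of 4 heavy atoms (3 oxygen, 1 phosphorus) in place of a hydrogen atom on an oxygen.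

The compounds shown leave open which configurations the undrawn centre of compound 4 contains. Going by these compounds, how a carboxylic acid in place of that group would read also remains open.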